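Halogens return to the ketone-side ring of compound 3

The source may hold more compounds than are shown below. What is called first, only, known or untested is meant among the compounds shown, and "the series" means these compounds.

Of the compounds shown here, three that share one core have been tested in a functional assay on NCI-H226 cells (Homo sapiens) for cytotoxicity, read by sulforhodamine B assay, with a stated time of 48 h, tested at 0.1 uM; a higher number here means a weaker effect of the compound at the concentration tested, a lower number a stronger effect. Compound 1 , `COc1cc(-c2cc(/C=C/C(=O)c3ccc(Cl)c(Cl)c3)[nH]n2)cc(OC)c1OC`, gives 103%. Compound 2 , `COc1ccc(-c2cc(/C=C/C(=O)c3cc(OC)c(OC)c(OC)c3)[nH]n2)cc1OC`, gives 90%. Compound 3 , `COc1ccc(C(=O)/C=C/c2cc(-c3cc(OC)c(OC)c(OC)c3)n[nH]2)cc1`, gives 102%, which is the second highest of the three numbers: its nearest neighbour is compound 1 , a number within the scatter of it, and its furthest is compound 2 , a number beyond the scatter below it.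

Compound 4 , `COc1cc(-c2cc(/C=C/C(=O)c3ccc(F)c(F)c3)[nH]n2)cc(OC)c1OC`, has not yet been measured. The change from compound 3 to compound 4 is 3,4-difluorophenyl in place of 4-methoxyphenyl on a carbonyl carbon.

Going by the values given here, one measured step bears on this change, since it also swaps the ring on the carbonyl carbon between a 4-methoxyphenyl and a dihalogenated phenyl: a number 1 percentage points lower from compound 1 to compound 3 (within the scatter). That step stayed within the scatter. Moving back from 4-methoxyphenyl to 3,4-difluorophenyl is therefore expected to give no step beyond the scatter in this assay, that is, an expected no change at the digits printed from compound 3 to compound 4 (within the scatter). For compound 4 the expected value in this assay is 102%, with a range from 92% to 112%.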

Compound 4, a percentage reported as activity, at one concentration (the size of the read-out at that concentration, not a potency): 97%
Beside the measured number, compound 4's estimate is 5 percentage points above it; measured number inside the range.
By their numbers in this assay, from the lowest: compounds 2, 4, 3 and 1 (each within the scatter of the next, the first and the last beyond it).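

In this assay, the ring on the carbonyl carbon has now been varied three ways on one core, and both new steps stay within the scatter: a number 5 percentage points lower from compound 3 to compound 4 (within the scatter) and a number 6 percentage points lower from compound 1 to compound 4 (within the scatter). Going by these compounds alone, the second step adds a comparison the earlier compounds did not offer, fluorine against chlorine on the same ring, so at this single concentration 3,4-difluorophenyl, 3,4-dichlorophenyl and 4-methoxyphenyl cannot be told apart at this position. Nothing measured here accounts for this similarity.

On these data alone, it remains open whether an aminophenyl or carboxyphenyl ring, or a longer chain on the carbonyl carbon, would give a step beyond the scatter. As far as these compounds go, it is also open whether these three rings would separate at a higher concentration, where the cells might respond more strongly.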